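4-Methylpiperazin-1-yl on the core of compound 1

The source may hold more compounds than are shown below. What is called first, only, known or untested is meant among the compounds shown, and "the series" means these compounds.

In an ADME assay on MRC5 cells (Homo sapiens) for cytotoxicity, read by neutral red uptake (on this read-out higher numbers stand for lower toxicity in this test and lower numbers for higher toxicity in this test), compound 1 (`O=c1[nH]c(SCc2cc([N+](=O)[O-])cc([N+](=O)[O-])c2)nc2ccccc12`) gives > 64000 nM, which is a limit and not a number. Compound 2 (`O=c1[nH]c(SCc2cccc([N+](=O)[O-])c2)nc2ccccc12`) also reports only a limit, > 64000 nM. Compound 3 (`O=c1[nH]c(SCc2cc([N+](=O)[O-])cc([N+](=O)[O-])c2)nc2c(Cl)cccc12`) likewise reports only a limit, > 64000 nM. Within the data shown here, the series so far therefore shows (the limit of > 64000 nM in this assay, at which 3 of the 3 values shown sit), so compound 1 has no exact place on the scale.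

Compound 4 (`CN1CCN(c2ccc3nc(SCc4cc([N+](=O)[O-])cc([N+](=O)[O-])c4)[nH]c(=O)c3c2)CC1`) carries 4-methylpiperazin-1-yl in place of hydrogen on an aromatic carbon of the core of compound 1 (4-methylpiperazin-1-yl in place of hydrogen on an aromatic carbon).

Two measured steps offer the nearest comparison. Hydrogen in place of nitro gives a step that the two limits leave unreadable from compound 1 to compound 2. Chloro in place of hydrogen gives a step that the two limits leave unreadable from compound 1 to compound 3. Neither step has a readable size, and neither introduces a ring on the core, so the data provide no measured size for this change. The working expectation in this assay is therefore a cautious one: a modest move towards lower numbers, with a further report at the limit quite possible. The expected size is an at least 1.4-fold lower number from compound 1 to compound 4 (0.15 log units; that floor lies within the scatter). For compound 4 the estimated value is 45000 nM, with an expected range of 15000 nM to 64000 nM.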

Compound 4, half-maximal cytotoxic concentration: 49000 nM
Estimate against measurement, compound 4: 1.1-fold (0.04 log units) below; the range from low to high includes it.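

In this assay compound 4 gives 49000 nM, the only exact value among the compounds shown, so this series now has one point on the scale. The other compounds remain at a limit: the limit of > 64000 nM in this assay, at which 3 of the 4 values shown sit. Placing 4-methylpiperazin-1-yl in place of hydrogen on this aromatic carbon of the shared core gives an at least 1.3-fold lower number from compound 1 to compound 4 (0.11 log units; that floor lies within the scatter), and this figure is only a floor, with the full size of the step unknown. Among these compounds, the other steps from compound 1 cannot be read, so this is the only change with any readable size, and that size does not establish a real difference in this test.

What the compounds shown leave open is which part of the 4-methylpiperazin-1-yl group goes with this result, and whether the same group would give a similar value at another place on the core. A morpholine or a piperazine without the methyl group, set on the same aromatic carbon, would test the ring and its substituent separately.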